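This account rests on a few compounds, and the source may have more. Where it says the series, first, only, none or still open, it means among the compounds named here.

Measured so far:
compound 1 `O=C(c1cccnc1)c1ccccc1O` gives 24600 nM
compound 2 `Cc1ccc(O)c(C(=O)c2cccnc2)c1` gives 8040 nM

Both numbers come from a functional assay on MCF7 cells (Homo sapiens) for cytotoxicity, read by sulforhodamine B assay, with a stated time of 48 h (a higher number here means a weaker inhibitor, a lower number a stronger inhibitor), and compound 2 holds the lower of the two. The next change, to compound 3 `O=C(c1cccnc1)c1cc(Br)ccc1O`, is bromo in place of methyl on an aromatic carbon, counted as bromo in place of methyl on an aromatic carbon and not yet measured. Going by the values given here, one measured step bears on it: a 3.1-fold lower number from compound 1 to compound 2 (0.49 log units; beyond the scatter) with methyl in place of hydrogen at that same place. Among the compounds with values here, this step is modest and stands alone, and no bromo compound has been measured. Compound 3 still carries a substituent at the place where compound 2 reached 8040 nM so a return towards compound 1 is not expected. Within the data shown here, the single step gives no firm direction for exchanging one substituent for another, and a change no larger than the scatter is expected in this assay with only a slight lean to a lower number. The estimate amounts to a 1.1-fold lower number from compound 2 to compound 3 (0.06 log units; within the scatter) as the expected step. Compound 3 is estimated at 7000 nM with an expected range from 2500 nM to 20000 nM in this assay.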

Compound 3, half-maximal inhibitory concentration: 53500 nM
Beside the measured number, compound 3's estimate is 7.6-fold (0.88 log units) below it; measured number outside the range, above it.
By their numbers in this assay, from the lowest: compound 2; then compound 1; then compound 3.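

In this assay the place para to a hydroxy group responds to which substituent it carries and not merely to whether one is present, with a 6.7-fold higher number from compound 2 to compound 3 (0.82 log units; beyond the scatter) on exchanging methyl for bromo. Bromo also moves the number in the opposite direction to methyl when each is compared with hydrogen at this same place: bromo gives a 2.2-fold higher number from compound 1 to compound 3 (0.34 log units; beyond the scatter) whereas methyl gives a 3.1-fold lower number from compound 1 to compound 2 (0.49 log units; beyond the scatter) on the same core. Filling this place therefore does not lower the number in itself, since among these three compounds compound 2 goes with that idea and compound 3 goes against it, and the methyl-to-bromo exchange is the largest step seen so far in the series.

From the compounds shown here alone, whether chloro, methoxy, an amine or a carboxylic acid at this place would side with methyl or with bromo remains open, as does whether the same substituents behave alike elsewhere on this ring. Nothing in the data at hand accounts for methyl and bromo pulling in opposite directions.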